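The compounds below may be only part of what the source reports. "The series", "measured", "known", "first", "only" and "open" are said of these compounds alone.

In a functional assay on LN-229 cells (Homo sapiens) for antiproliferative activity, with a stated time of 72 h (on this read-out higher numbers stand for weaker inhibition and lower numbers for stronger inhibition), compound 1 `Cn1cc(-c2nn(C(C)(C)C)c3ncnc(N)c23)c2ccccc21` returns > 78300 nM as its result, which is a limit and not a number. Among the measured compounds shown here, compound 2 `Nc1ncnc2c1c(-c1c[nH]c3ccccc13)nn2CC1CCNCC1` gives 80600 nM as the only true number so far, with no other measured number to set it against. Compound 3 `CC(C)(C)n1nc(-c2c[nH]c3ccccc23)c2c(N)ncnc21` has not yet been measured and carries tert-butyl in place of (piperidin-4-yl)methyl on an aromatic nitrogen as its one difference. For the measured compounds named here, with no measured step to go on, the expected change a 1.3-fold lower number from compound 2 to compound 3 (0.13 log units; within the scatter) is none beyond the scatter. The estimate for compound 3 is 60000 nM with an expected range from 20000 nM to 120000 nM as its span.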

Compound 3, half-maximal inhibitory concentration: 39200 nM
Compound 3: the middle estimate sits 1.5-fold (0.18 log units) above what was measured, and the stated range covers the measured number.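

In this assay, the group on this aromatic nitrogen of the five-membered ring does move the number: tert-butyl in place of (piperidin-4-yl)methyl gives a 2.1-fold lower number from compound 2 to compound 3 (0.31 log units; beyond the scatter), a modest step. In a different place, hydrogen in place of methyl on an aromatic nitrogen gives an at least 1.9-fold lower number from compound 1 to compound 3 (0.30 log units; that floor lies within the scatter), so only a floor can be read. Compound 1 stands at a limit and not at a number: the limit of > 78300 nM in this assay, at which 1 of the 3 values shown sits.

From the compounds shown here alone, how a carboxylic acid or a short open chain ending in an amine would behave on the first nitrogen remains open.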